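Paw edema series: extending from compound 1 to compound 4

The source may hold more compounds than are shown below. What is called first, only, known or untested is meant among the compounds shown, and "the series" means these compounds.

Measured so far in a functional assay on the whole organism (strain Wistar) for inhibition, with Rattus norvegicus as the target, read by paw edema, with a stated time of 30 min, at a dose of 10 mg/kg by the intraperitoneal route; on this read-out lower numbers stand for less inhibition and higher numbers for more inhibition at the one dose given (going by the name of the read-out):
compound 1 `O=C(N/N=C/c1ccccc1)c1cccnc1Nc1cccc(C(F)(F)F)c1` gives 60.4%
compound 2 `O=C(N/N=C/c1cccc(F)c1)c1cccnc1Nc1cccc(C(F)(F)F)c1` gives 58.3%
compound 3 `O=C(N/N=C/c1cccc(Cl)c1)c1cccnc1Nc1cccc(C(F)(F)F)c1` gives 77.8%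

Compound 1 and compound 2 sit within the scatter of each other, shown by the step of a number 2.1 percentage points lower from compound 1 to compound 2 (within the scatter). Compound 3 stands apart from both: the step of a number 17.4 percentage points higher from compound 1 to compound 3 (beyond the scatter) and the step of a number 19.5 percentage points higher from compound 2 to compound 3 (beyond the scatter) are each beyond the scatter, so compound 3 is the only one of the three that clearly separates.

The next compound, compound 4 `COc1ccc(/C=N/NC(=O)c2cccnc2Nc2cccc(C(F)(F)F)c2)cc1OC`, differs from compound 1 as follows: 3,4-dimethoxyphenyl in place of phenyl on a carbon with a double bond to nitrogen. The ring that changes is the same one varied in the measured steps, but none of those steps tried a methoxy group or two substituents at once; the fluoro step stayed within the scatter and the chloro step was modest. Among the compounds with values here, no measured step therefore bears directly on this change, and only a small shift is expected. For compound 4 the estimate is 62%, with a range from 45% to 78%, which means an expected step of a number 1.6 percentage points higher from compound 1 to compound 4 (within the scatter).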

Compound 4, a percentage reported as inhibition, in the whole organism at one dose (the size of the read-out at that dose, not a potency): 60.1%
Estimate against measurement, compound 4: 1.9 percentage points above, within the range that was stated.
By their numbers in this assay, from the lowest: compounds 2, 4 and 1 (each within the scatter of the next); then compound 3.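

In this assay, 3,4-dimethoxyphenyl in place of phenyl on the carbon with a double bond to nitrogen gives a number 0.3 percentage points lower from compound 1 to compound 4 (within the scatter), so adding this larger, oxygen-bearing group does not move the read-out beyond the scatter. Within the data shown here, the comparison with the 3-fluorophenyl compound reads the same way, at a number 1.8 percentage points higher from compound 2 to compound 4 (within the scatter), while a number 17.7 percentage points lower from compound 3 to compound 4 (beyond the scatter) leaves 3-chlorophenyl as the only group at this position that separates from the others. No evidence is available to explain the difference between these groups.

The compounds shown leave open how a single methoxy group, a bromo group, an amine or a carboxylic acid on this ring would read. They also leave open whether the gap seen at the one dose given would hold across other doses.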